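Removing the Bromo Group from Compound 1: What to Expect

The source may report more compounds than this note shows. Statements on the series, on what has been measured and on what is new or still open speak of the compounds shown alone.

Measured compounds:
Compound 1 `COc1cc(C(=O)/C=C\Nc2ccc(-c3nc4cc(OC)c(OC)c(OC)c4s3)cc2)c(Br)c(OC)c1OC`: 15600 nM
Compound 2 `COc1cc(OC)c2sc(-c3ccc(N/C=C\C(=O)c4cc(OC)c(OC)c(OC)c4Br)cc3)nc2c1`: 16100 nM
Compound 3 `COc1cc(C(=O)/C=C\Nc2ccc(-c3nc4cc(OC)c(OC)c(OC)c4s3)cc2C)c(Br)c(OC)c1OC`: 7300 nM

Of the compounds shown here, three sharing one core have been tested in a functional assay on MDA-MB-231 cells (Homo sapiens) for antiproliferative activity, read by sulforhodamine B assay, with a stated time of 48 h; on this read-out higher numbers stand for weaker inhibition and lower numbers for stronger inhibition. Compound 1 gives 15600 nM, which is the second highest of the three numbers. Its nearest neighbour is compound 2, and the step of a 1.0-fold higher number from compound 1 to compound 2 (0.01 log units; within the scatter) is within the scatter, so the two are indistinguishable on this read-out. Its furthest neighbour is compound 3, and the step of a 2.1-fold lower number from compound 1 to compound 3 (0.33 log units; beyond the scatter) is a modest shift toward stronger inhibition.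

Compound 4 `COc1cc(C(=O)/C=C\Nc2ccc(-c3nc4cc(OC)c(OC)c(OC)c4s3)cc2)cc(OC)c1OC` has not yet been measured. It differs from compound 1 in one place: hydrogen in place of bromo on an aromatic carbon.

For the measured compounds named here, none of the measured steps removes a bromo group, so no step bears directly on this change. The two steps that are known, from compound 1 to compound 2 and from compound 1 to compound 3, show that single small edits on this core have moved the number in this assay by at most a modest amount, in either direction or not at all. On that basis, the step is expected to be small, with no strong reason to favour one direction: the expected step is a 1.2-fold lower number from compound 1 to compound 4 (0.08 log units; within the scatter).

Compound 4 is therefore estimated at 13000 nM, with a likely range from 5000 nM to 35000 nM.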

Compound 4, half-maximal inhibitory concentration: 16500 nM
For compound 4 the middle estimate is 1.3-fold (0.10 log units) below the measured one; low and high end bracket the measured number.
By their numbers in this assay, from the lowest: compound 3; then compounds 1, 2 and 4 (each within the scatter of the next).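

Within this assay, putting hydrogen in place of bromo on this aromatic carbon, which is ortho to a large group and ortho to a methoxy group, gives a 1.1-fold higher number from compound 1 to compound 4 (0.02 log units; within the scatter) and so produces no change that this read-out can distinguish. The earlier steps shown here concerned a methoxy group and a methyl group and said nothing about this carbon; this step shows that compound 1 does not need its bromo group, a single heavy atom, to hold its number in this assay. No measured information is available to account for this outcome.

From the compounds shown here alone, only bromo and hydrogen are seen on this carbon, so it remains open whether an amine, a carboxylic acid or a longer alkyl chain there would likewise leave the number in place. Also open is whether the modest gain seen on adding a methyl group in the presence of bromo would persist with hydrogen on this carbon, as the compounds shown include no pair that tests it.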